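This account rests on a few compounds, and the source may have more. Where it says the series, first, only, none or still open, it means among the compounds named here.

In a functional assay on SMMC-7721 cells (Homo sapiens) for inhibition, read by CCK-8 assay, with a stated time of 72 h, tested at 2 uM (a higher number here means more inhibition of growth at the concentration tested, a lower number less inhibition of growth), three compounds have been measured so far:

- compound 1 `COc1ccc(SCc2ccc(C(=O)Nc3ccccc3N)cc2)cc1` gives 33.1%
- compound 2 `Nc1ccccc1NC(=O)/C=C/c1ccc(CSc2ccc(F)cc2)cc1` gives 18.3%
- compound 3 `COC(=O)c1ccccc1SCc1ccc(C(=O)Nc2ccccc2N)cc1` gives 18%

Compound 1 has the highest number of the three, and its gaps down to compound 2 and to compound 3 both lie beyond the scatter. Compound 2 and compound 3 lie within the scatter of each other.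

The next compound to be tested, compound 4 `Nc1ccccc1NC(=O)c1ccc(CSc2ccc(Cl)cc2)cc1`, keeps the rest of compound 1 and carries chloro in place of methoxy on an aromatic carbon, para to a large group (chloro in place of methoxy on an aromatic carbon). The same difference, cut one bond further out, reads 4-methoxyphenyl to 4-chlorophenyl.

Within the data shown here, no two measured compounds differ in one place only, so no measured step speaks directly to this change. In this assay a modest step is expected, downward if anything, and none beyond the scatter is predicted. The lean is downward because compound 1 at 33.1% sits at the top of a very small set. The expected shift is a number 6.1 percentage points lower from compound 1 to compound 4 (within the scatter) and would stay within the scatter. The estimate for compound 4 is 27% with an expected range from 14% to 42% in this read-out.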

Compound 4, percent growth inhibition at one concentration: 2.93%
Beside the measured number, compound 4's estimate is 24.1 percentage points above it, outside the stated range (below it).
By their numbers in this assay, from the lowest: compound 4; then compounds 3 and 2 (each within the scatter of the next); then compound 1.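

In this assay, among these compounds, chloro in place of methoxy on an aromatic carbon gives a number 30.2 percentage points lower from compound 1 to compound 4 (beyond the scatter), the first step here that can be read at a single place. It shows that this position, para to a large group, is not indifferent to what it carries. The earlier compounds, none of which differed from another in one place only, could not show that exchanging this one group, with the rest of compound 1 kept, is enough to produce a large loss of growth inhibition at the concentration tested, and nothing available here bears on why the number falls with this change.

A single step leaves open whether the fall follows from losing methoxy or from gaining chloro, and a plain hydrogen, a methyl, an ethoxy or an amine at the same position would help to separate the two. It also leaves open whether the same exchange would move the number as far in a compound built like compound 2, whose other parts differ.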